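A few compounds are considered here, and "the series" means these few. Any claim that something is new, unique, unknown or untested is made for them only; others in the source may bear on it.

Working notes on the series. Compound 1 `Oc1ccc(-c2cc(-c3ccoc3)cc(-c3ccc(O)cc3)n2)cc1` is the reference point: in an assay on isolated protein for inhibition of DNA topoisomerase 1 (Homo sapiens), with a stated time of 30 min, tested at 100 uM (a lower number here means a weaker effect, a higher number a stronger effect of the compound at the concentration tested), compound 1 gives 74.9%. Among the measured compounds shown here, compound 2 `Oc1ccc(-c2cc(-c3cccnc3)cc(-c3cccc(O)c3)n2)cc1` stands lowest of the two numbers so far; in this assay compound 2 gives 5.9%, a reading beyond the scatter below that of compound 1. Compound 3 `Oc1ccc(-c2cc(-c3cccnc3)cc(-c3ccc(O)cc3)n2)cc1` has not been measured yet. It differs from compound 2 in one place: 4-hydroxyphenyl in place of 3-hydroxyphenyl on an aromatic carbon. For the measured compounds named here, no step between measured compounds isolates this exchange, so its size is not known directly. Compound 3 carries at this position the same 4-hydroxyphenyl group that compound 1 carries, and compound 1 gives 74.9%; on that basis an upward step is expected for compound 3, clearly beyond the scatter, yet the reading is expected to stay short of that of compound 1. The expected step is a number 34.1 percentage points higher from compound 2 to compound 3 (beyond the scatter). For compound 3 the estimate in this assay is 40%, with a range from 12% to 70%.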

Compound 3, a percentage reported as inhibition, at one concentration (the size of the read-out at that concentration, not a potency): 8.7%
The estimate for compound 3 lay 31.3 percentage points above the measured number; measured number below the stated range.
By their numbers in this assay, from the lowest: compounds 2 and 3 (each within the scatter of the next); then compound 1.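

In this assay 4-hydroxyphenyl in place of 3-hydroxyphenyl, on the aromatic carbon next to the ring nitrogen, gives only a small difference (a number 2.8 percentage points higher from compound 2 to compound 3 (within the scatter)), so with pyridin-3-yl in the shared core this exchange does not separate the two compounds. The large step lies at the other position, where pyridin-3-yl stands in place of furan-3-yl (a number 66.2 percentage points lower from compound 1 to compound 3 (beyond the scatter)), so 4-hydroxyphenyl alone does not carry the reading of compound 1. Nothing at hand explains either step.

Going by these compounds, whether 3-hydroxyphenyl and 4-hydroxyphenyl also read alike with furan-3-yl in the core remains open. Also open, on these data alone, is what a methoxy group in place of the hydroxyl, or an amine on that ring, would give at this position.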